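Swapping the Fumarate Cap for a Phosphate Cap

A few compounds are considered here, and "the series" means these few. Any claim that something is new, unique, unknown or untested is made for them only; others in the source may bear on it.

Compound 1 `CCCN(C(=O)OCOC(=O)/C=C/C(=O)O)C(=O)c1cn2ncnc(Nc3cc(C(=O)NC4CC4)ccc3C)c2c1C` is measured in a physicochemical assay for pharmacokinetics, at 37 degrees C, at pH 1 (on this read-out lower numbers stand for a shorter-lived compound and higher numbers for a longer-lived compound), at 79.4 h, the higher of the two numbers recorded. Compound 2 `CCCNC(=O)c1cn2ncnc(N(C(=O)OCOP(=O)(O)O)c3cc(C(=O)NC4CC4)ccc3C)c2c1C` gives 8.5 h in this assay, a gap beyond the scatter. Compound 3 `CCCN(C(=O)OCOP(=O)(O)O)C(=O)c1cn2ncnc(Nc3cc(C(=O)NC4CC4)ccc3C)c2c1C` differs from compound 1 by a group of 4 heavy atoms (3 oxygen, 1 phosphorus; no ring) in place of a group of 7 heavy atoms (4 carbon, 3 oxygen; no ring), on an oxygen on a saturated carbon. Within the data shown here, no measured pair walks exactly this step, so the expectation rests on compound 2, whose 8.5 h is the only number here for a group containing phosphorus. The expected step is a 4.0-fold lower number from compound 1 to compound 3 (0.60 log units; beyond the scatter), a drop beyond the scatter. Compound 3 is estimated at 20 h, within 5 h to 80 h.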

Compound 3, half-life: 26.8 h
Compound 3: the middle estimate sits 1.3-fold (0.13 log units) below what was measured; the measured number falls inside the stated range.
By their numbers in this assay, from the lowest: compound 2; then compound 3; then compound 1.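

Replacing the (2-carboxyethenyl)carbonyl group with the phosphorus-containing group, on an oxygen on a saturated carbon, gives a 3.0-fold lower number from compound 1 to compound 3 (0.47 log units; beyond the scatter) in this assay. Among these compounds, this is the first pair here that differs in only one place, so the effect of changing this cap can be read on its own, and the change shortens the half-life without bringing it into the range of the scatter. Nothing measured here explains the size of this step. On these data alone, how a cap carrying an amine, or a simple acetyl group, would behave on this oxygen remains open.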